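The compounds below may be only part of what the source reports. "The series", "measured", "known", "first", "only" and "open" are said of these compounds alone.

Measured so far:

Compound 1, `CCCCCCCc1cc2c(=O)n(CC#N)cnc2s1`: in an ADME assay on THP-1 cells (Homo sapiens) for cytotoxicity, read by MTT assay, with a stated time of 11 days (on this read-out lower numbers stand for stronger inhibition of growth and higher numbers for weaker inhibition of growth), compound 1 gives > 100 ug/mL, which is a limit of the assay and not a number.

Compound 2, `CCCCCCCc1cc2c(=O)n(CCCBr)cnc2s1`: in this assay compound 2 gives > 100 ug/mL, again a limit rather than a number.

Compound 2 therefore stands at the limit of > 100 ug/mL in this assay, at which 2 of the 2 values shown sit, so its position among the measured compounds cannot be placed more closely than that. The step from it to compound 3, `CCCCCCCc1cc2c(=O)n(CCN=[N+]=[N-])cnc2s1`, is azido in place of bromomethyl on a saturated chain carbon, two bonds along the chain from an aromatic nitrogen. For the measured compounds named here, the only measured step that touches this part of the molecule is a step that the two limits leave unreadable from compound 1 to compound 2, and since both of its end points are limits it says nothing about how large a change of the side chain on the aromatic nitrogen can shift growth inhibition of these cells. The measured data thus give no readable step at all, and no direction can be taken from them. The expectation for compound 3 is that it also returns a limit rather than a number, with the expected step that the limit leaves unreadable from compound 2 to compound 3 sitting within the usual scatter. The estimate for compound 3 is 150 ug/mL, with a range from 50 ug/mL to 500 ug/mL.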

Compound 3, concentration for 50% growth inhibition: > 100 ug/mL
Compound 3 was reported as a limit; the forecaster's own chance of this, stated with the estimate: 85%; the middle value lies beyond the limit too.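

For the compounds shown here, no step among compound 1, compound 2 and compound 3 can be read, since all of them stop at a limit of the assay rather than a number: the limit of > 100 ug/mL in this assay, at which 3 of the 3 values shown sit.

The compounds shown leave open whether any side chain on the aromatic nitrogen of the shared core can give a readable number for growth inhibition of these cells.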